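Trimmed alkyl chain on the pyranone-type core

This account rests on a few compounds, and the source may have more. Where it says the series, first, only, none or still open, it means among the compounds named here.

For the measured compounds named here, compound 2 `CCCCCc1cc(Nc2ccc(OC)cc2)cc(=O)o1` is the only compound of the pair with a number in a functional assay on KBVIN cells (Homo sapiens) for cytotoxicity, read by MTT assay, with a stated time of 72 h; a lower number here means that less compound is needed, a higher number that more compound is needed for the effect; compound 2 gives 4.84 uM. Compound 1 `COc1ccc(Nc2cc(C)oc(=O)c2)cc1` reaches only the limit > 30 uM in this assay. Going by the values given here, the one measured step, an at least 6.1-fold lower number from compound 1 to compound 2 (0.79 log units; beyond the scatter), rests on (the limit of > 30 uM in this assay, at which 1 of the 2 values shown sits). Compound 3 `COc1ccc(Nc2cc(C(C)C)oc(=O)c2)cc1` differs from compound 2 by isopropyl in place of pentyl on an aromatic carbon. The chain shortens toward compound 1, so a step back in that direction is expected in this assay, smaller than the measured one. For compound 3 an estimated 15 uM (range 5 uM to 40 uM) is expected, meaning a 3.1-fold higher number from compound 2 to compound 3 (0.49 log units; beyond the scatter).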

Compound 3, concentration for half-maximal effect: > 30 uM
Compound 3: a limit, no number (the forecaster's own chance of this, stated with the estimate: 35%); at least 2.0-fold (0.30 log units) between middle value and limit.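

In this assay, for the compounds shown here, pentyl is the only group at this aromatic carbon so far that yields a number, and isopropyl in its place gives an at least 6.1-fold higher number from compound 2 to compound 3 (0.79 log units; beyond the scatter). Compound 3 reaches only a limit, > 30 uM, not a number. The comparison of compound 1 with compound 3 cannot be read, and the lower end of the series remains bounded: the limit of > 30 uM in this assay, at which 2 of the 3 values shown sit.

Isopropyl differs from pentyl in both length and branching, so a straight propyl or butyl chain would be needed to separate the two. Also open, on these data alone, is what a longer chain such as heptyl, or an amine at the end of the pentyl chain, would give at this carbon.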